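The source may report more compounds than this note shows. Statements on the series, on what has been measured and on what is new or still open speak of the compounds shown alone.

Compound 1 `COc1cc2ncnc(Nc3cccc(F)c3)c2cc1OCCCCC(=O)Nc1ccc(S(N)(=O)=O)cc1` gives in a functional assay on A549 cells (Homo sapiens) for antiproliferative activity, read by MTT assay, with a stated time of 72 h (a higher number here means a weaker inhibitor, a lower number a stronger inhibitor), the limit > 40000 nM, not a number.
Compound 2 `COc1cc2ncnc(Nc3ccc(Cl)cc3)c2cc1OCCCCC(=O)Nc1ccc(S(N)(=O)=O)cc1` gives in this assay the limit > 40000 nM, not a number.
Compound 3 `COc1cc2ncnc(Nc3cc(F)c(F)c(F)c3)c2cc1OCCCCC(=O)Nc1ccc(S(N)(=O)=O)cc1` gives in this assay the limit > 40000 nM, not a number.

Compound 3 stands at the limit of this assay, and nothing separates it from the other two compounds, since all three sit at the limit of > 40000 nM in this assay, at which 3 of the 3 values shown sit. The steps from compound 1 to compound 2 a step that the two limits leave unreadable from compound 1 to compound 2, from compound 1 to compound 3 a step that the two limits leave unreadable from compound 1 to compound 3 and from compound 2 to compound 3 a step that the two limits leave unreadable from compound 2 to compound 3 therefore cannot be read: each joins two limits.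

Compound 4 `COc1ccccc1Nc1ncnc2cc(OC)c(OCCCCC(=O)Nc3ccc(S(N)(=O)=O)cc3)cc12` differs from compound 3 in one place: 2-methoxyphenyl in place of 3,4,5-trifluorophenyl on a nitrogen on an aromatic ring. This change is of the same kind as the three measured ones, an exchange of the aryl group on a nitrogen on an aromatic ring, and none of those three yielded a readable step. Among the compounds with values here, no measured step, then, bears on it with a size. The shared core and the chain carrying the sulfonamide are untouched, and every variant of the aryl group measured so far stayed at the limit.

Compound 4 is therefore expected to remain at the limit of this assay, with the step of a number no higher from compound 3 to compound 4 (the limit leaves the size open) expected to be no more than a formality of bookkeeping; the estimate for compound 4 is 40000 nM, between 12000 nM and 120000 nM.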

Compound 4, half-maximal inhibitory concentration: 24100 nM
Estimate against measurement, compound 4: 1.7-fold (0.22 log units) above, and the stated range covers the measured number.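

With 2-methoxyphenyl on a nitrogen on an aromatic ring, compound 4 is the only compound shown that gives a number in this assay, 24100 nM. The others remain at a limit: the limit of > 40000 nM in this assay, at which 3 of the 4 values shown sit.

This position can therefore carry a group that brings the read-out off that limit, and the steps can now be given as an at least 1.6-fold lower number from compound 3 to compound 4 (0.22 log units; that floor lies within the scatter), an at least 1.6-fold lower number from compound 2 to compound 4 (0.22 log units; that floor lies within the scatter) and an at least 1.6-fold lower number from compound 1 to compound 4 (0.22 log units; that floor lies within the scatter). From the compounds shown here alone, each of these is only a floor, so the full size of the change remains unknown, and the steps among compounds 1, 2 and 3 still cannot be read.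

Going by these compounds, whether the number depends on the methoxy group itself or on the aryl group as a whole stays open, as does whether 2-hydroxyphenyl or 2-ethoxyphenyl in the same place would also give a number. Also open, on these data alone, is how far a shorter or longer chain, or a carboxylic acid in place of the sulfonamide, would move the value of compound 4.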